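The source may hold more compounds than are shown below. What is called first, only, known or untested is meant among the compounds shown, and "the series" means these compounds.

The measured compounds:
compound 1, `Cc1ccc(N(C)S(=O)(=O)C2CC3OC2C(c2ccc(NC(=O)CCCCCCC(=O)O)cc2)=C3c2ccc(O)cc2)cc1`, in a functional assay on MCF7 cells (Homo sapiens) for antiproliferative activity, read by MTT assay, with a stated time of 72 h; on this read-out lower numbers stand for stronger inhibition and higher numbers for weaker inhibition: 23200 nM
compound 2, `CCN(c1ccccc1)S(=O)(=O)C1CC2OC1C(c1ccc(NC(=O)CCCCCCC(=O)O)cc1)=C2c1ccc(O)cc1`, in this assay: 19100 nM
compound 3, `CCN(c1cccc(C)c1)S(=O)(=O)C1CC2OC1C(c1ccc(NC(=O)CCCCCCC(=O)O)cc1)=C2c1ccc(O)cc1`, in this assay: 31800 nM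

Among these three, compound 1 stands second highest. Its nearest neighbour gives a 1.2-fold lower number from compound 1 to compound 2 (0.08 log units; within the scatter), and its furthest gives a 1.4-fold higher number from compound 1 to compound 3 (0.14 log units; within the scatter), so all three sit within the scatter of one another.

Compound 4, `CCN(c1ccc(OC)cc1)S(=O)(=O)C1CC2OC1C(c1ccc(NC(=O)CCCCCCC(=O)O)cc1)=C2c1ccc(O)cc1`, has not yet been measured in this assay. It differs from compound 1 in one place: ethyl(4-methoxyphenyl)amino in place of methyl(4-methylphenyl)amino on a sulfonyl sulfur. Among the compounds with values here, three measured steps bear on this exchange. Two of them also replace the whole group on the sulfonyl sulfur, a 1.2-fold lower number from compound 1 to compound 2 (0.08 log units; within the scatter) and a 1.4-fold higher number from compound 1 to compound 3 (0.14 log units; within the scatter), and the third puts methyl in place of hydrogen on an aromatic carbon of that group, a 1.7-fold higher number from compound 2 to compound 3 (0.22 log units; within the scatter). None of these moves the number beyond the scatter, in either direction. The step from compound 1 to compound 4 is therefore expected to be a 1.1-fold lower number from compound 1 to compound 4 (0.02 log units; within the scatter). Compound 4 is estimated at 22000 nM, with a range from 11000 nM to 45000 nM.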

Compound 4, half-maximal inhibitory concentration: 20300 nM
Estimate against measurement, compound 4: 1.1-fold (0.03 log units) above; measured number inside the range.
By their numbers in this assay, from the lowest: compounds 2, 4, 1 and 3 (each within the scatter of the next).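

In this assay the exchange brings in ethyl(4-methoxyphenyl)amino, a group with more heavy atoms and a hydrogen-bond acceptor on the sulfonyl sulfur, yet a 1.1-fold lower number from compound 1 to compound 4 (0.06 log units; within the scatter) stays within the scatter. Methoxy on an aromatic carbon gives a 1.1-fold higher number from compound 2 to compound 4 (0.03 log units; within the scatter) and 4-methoxyphenyl on the sulfonamide nitrogen gives a 1.6-fold lower number from compound 3 to compound 4 (0.19 log units; within the scatter), so neither exchange moves the number beyond the scatter, and an oxygen-bearing group now joins the methyl-substituted and unsubstituted rings in that same narrow band. No measurement shown here offers an explanation for this result.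

From the compounds shown here alone, whether an amine or a carboxylic acid on the aromatic ring would move the number beyond the scatter remains open. So does the effect of a longer chain in place of ethyl on the sulfonamide nitrogen.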